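The compounds below may be only part of what the source reports. "The series", "measured", "known", "first", "only" and "open" are said of these compounds alone.

Values in an assay on isolated protein for inhibition of cytochrome P450 26A1 (Homo sapiens), read by scintillation counting; a higher number here means a weaker inhibitor, a lower number a stronger inhibitor:
compound 1 `CC(C)(C(=O)O)C(c1ccc(Nc2ccc3ccccc3c2)cc1)n1ccnc1`: 300 nM
compound 2 `CNC(=O)C(C)(C)C(c1ccc(Nc2ccc3ccccc3c2)cc1)n1ccnc1`: 12 nM
compound 3 `CC(C)(C(=O)O)C(c1ccc(Nc2ccc3ccccc3c2)cc1)n1cncn1`: > 1000 nM, a limit of the assay and not a number.

Compound 3 stands at the weak end of the three; its result in this assay is only a limit (the limit of > 1000 nM in this assay, at which 1 of the 3 values shown sits), so its distance from compound 1 is known only as an at least 3.3-fold higher number from compound 1 to compound 3 (0.52 log units; beyond the scatter). Compound 4 `CNC(=O)C(C)(C)C(c1ccc(Nc2ccc3ccccc3c2)cc1)n1cncn1` carries the change (methylamino in place of hydroxy on a carbonyl carbon). The same change has been measured once in this series, as a 25-fold lower number from compound 1 to compound 2 (1.40 log units; beyond the scatter), a large step to a lower number. Carried over to compound 4, the expected step is an at least 16-fold lower number from compound 3 to compound 4 (1.22 log units; beyond the scatter), toward a lower number and beyond the scatter. Compound 4 is therefore estimated at 60 nM in this assay, with a range from 20 nM to 300 nM.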

Compound 4, half-maximal inhibitory concentration: 350 nM
Compound 4: middle estimate off by 5.8-fold (0.77 log units), on the low side; measured number above the stated range.
By their numbers in this assay, from the lowest: compound 2; then compounds 1 and 4 (each within the scatter of the next). At a limit, above all of these: compound 3.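

In this assay, methylamino in place of hydroxy on a carbonyl carbon also lowers the number when 1H-1,2,4-triazol-1-yl is present, giving an at least 2.8-fold lower number from compound 3 to compound 4 (0.45 log units; beyond the scatter). With methylamino held constant, 1H-1,2,4-triazol-1-yl in place of 1H-imidazol-1-yl now has a full measured size, a 29-fold higher number from compound 2 to compound 4 (1.46 log units; beyond the scatter), so this group change is large on the amide core. The size of the methylamino step on the two cores cannot be compared: the same change on two cores in this assay, a 25-fold lower number (1.40 log units; beyond the scatter) from compound 1 to compound 2 and an at least 2.8-fold lower number (0.45 log units; beyond the scatter) from compound 3 to compound 4; the limit leaves it open whether they differ. Also open, going by these compounds, is how dimethylamino or ethylamino on the carbonyl carbon would read with either ring group.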